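Removing a Dimethylamino Group: Expected Permeability of Compound 4

The compounds below may be only part of what the source reports. "The series", "measured", "known", "first", "only" and "open" are said of these compounds alone.

Three compounds have been measured in an ADME assay for permeability, using PAMPA, with a stated time of 30 min, at pH 7.4; on this read-out lower numbers stand for lower permeability and higher numbers for higher permeability:

Compound 1, `CN(C)c1cccc(Oc2ccc3c(NCCCNCc4ccco4)ccnc3c2)c1`, gives 317 10^-6 cm/s.
Compound 2, `COc1ccc(F)cc1CNCCCNc1ccnc2cc(Oc3cccc(N(C)C)c3)ccc12`, gives 317 10^-6 cm/s.
Compound 3, `COc1cccc(CNCCCNc2ccnc3cc(Oc4cccc(N(C)C)c4)ccc23)c1O`, gives 317 10^-6 cm/s.

All three share the same core and differ only in the aromatic group on the saturated chain carbon bound to an amine nitrogen. Compound 2 stands level with compound 1 and compound 3: the steps of no change at the digits printed from compound 1 to compound 2 (within the scatter), no change at the digits printed from compound 1 to compound 3 (within the scatter) and no change at the digits printed from compound 2 to compound 3 (within the scatter) show that swapping the furan-2-yl for a 5-fluoro-2-methoxyphenyl or a 2-hydroxy-3-methoxyphenyl group leaves the read-out unmoved.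

The unmeasured compound 4, `COc1ccc(F)cc1CNCCCNc1ccnc2cc(Oc3ccccc3)ccc12`, is made from compound 2 by a change at the other end of the molecule: hydrogen in place of dimethylamino on an aromatic carbon. Among the compounds with values here, none of the measured steps touches this position; they all concern the group on the chain carbon, so no measured step bears directly on it. The three measured values agree closely, which suggests the read-out is not easily moved by changes of this size. The step of no change at the digits printed from compound 2 to compound 4 (within the scatter) is therefore expected to be none beyond the scatter, in either direction. Compound 4 is estimated to give 317 10^-6 cm/s, with a range from 160 10^-6 cm/s to 450 10^-6 cm/s.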

Compound 4, apparent permeability: 317 10^-6 cm/s
The estimate for compound 4 equals the measured number at the digits printed; low and high end bracket the measured number.
By their numbers in this assay, from the lowest: compounds 1, 2, 3 and 4 (each within the scatter of the next).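

In this assay, within the data shown here, the step of no change at the digits printed from compound 2 to compound 4 (within the scatter) is the first reading at this end of the molecule, since the earlier compounds differ only in the group on the saturated chain carbon. It shows that, in this one pair, the read-out does not depend on the dimethylamino group: with hydrogen on that aromatic carbon, so that 3-(dimethylamino)phenoxy becomes phenoxy, compound 4 stands level with compound 2. Nothing shown here offers an explanation for this result.

Still open, going by these compounds, is how other groups on the same aromatic carbon, such as a carboxylic acid, a primary amine or a methoxy group, would read in this assay, since one replacement by hydrogen says nothing about what a new group would do there. Also open, on these data alone, is whether hydrogen in place of dimethylamino would read the same with furan-2-yl or 2-hydroxy-3-methoxyphenyl on the chain carbon, and how a longer chain between the core and the amine nitrogen would read.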